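Extending the alkoxy chain on the shared core of compound 2

The source may hold more compounds than are shown below. What is called first, only, known or untested is meant among the compounds shown, and "the series" means these compounds.

Compound 1 `Oc1cncc(N2CCCNCC2)c1` carries a hydroxyl on the aromatic ring; in an assay on cell membranes for binding affinity to Neuronal acetylcholine receptor; alpha4/beta2 (Rattus norvegicus), read by radioligand binding (on this read-out lower numbers stand for stronger inhibition and higher numbers for weaker inhibition), compound 1 gives 2.4 nM. Compound 2 `COc1cncc(N2CCCNCC2)c1` is its methyl ether, and in this assay compound 2 gives 1.9 nM. Among the compounds with values here, the only step that has been measured, a 1.3-fold lower number from compound 1 to compound 2 (0.10 log units; within the scatter), is the change of methyl in place of hydrogen on an oxygen on an aromatic ring. Among the two numbers known so far, the number of compound 2 is the lower one, but its distance to compound 1 is within the scatter, so no order between them can be claimed.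

Compound 3 `CC(C)COc1cncc(N2CCCNCC2)c1` has not been measured. It differs from compound 2 by isopropyl in place of hydrogen on a saturated chain carbon bound to an oxygen on an aromatic ring; cut one bond further out, the change reads methoxy to isobutoxy. Within the data shown here, the one measured step bears on it only indirectly, since it shows that the oxygen tolerates a small group, and that step stayed within the scatter. A chain of three further carbons goes beyond anything measured here, and so a moderate rise in the number of compound 3 is expected, a 4.2-fold higher number from compound 2 to compound 3 (0.62 log units; beyond the scatter). The estimate for compound 3 in this assay is 8 nM, with a range from 2 nM to 40 nM.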

Compound 3, half-maximal inhibitory concentration: 2.2 nM
Estimate against measurement, compound 3: 3.6-fold (0.56 log units) above; measured number inside the range.
By their numbers in this assay, from the lowest: compounds 2, 3 and 1 (each within the scatter of the next).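

With isobutoxy in place of methoxy, the position on the aromatic ring is shown to carry far more than the small methyl of compound 2, since isopropyl on the saturated chain carbon bound to the oxygen gives a 1.2-fold higher number from compound 2 to compound 3 (0.06 log units; within the scatter) in this assay. The comparison with the free hydroxyl of compound 1 reads the same way, with a 1.1-fold lower number from compound 1 to compound 3 (0.04 log units; within the scatter) as the step for isobutyl in place of hydrogen on the oxygen, so hydrogen, methyl and isobutyl on this oxygen cannot be told apart in this read-out, and the three compounds form one group with no order among them. Nothing available here bears on why the numbers of these three compounds lie so close together.

The compounds shown leave open how far this holds, as a longer chain such as n-hexyl, or a benzyl group, on the same oxygen could still separate from these three numbers. They also leave open whether a chain ending in an amine or a carboxylic acid would fall within the same scatter or beyond it.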